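Compound 4: the open stereocentre drawn S

The compounds below may be only part of what the source reports. "The series", "measured", "known", "first", "only" and "open" are said of these compounds alone.

In a functional assay on U-373MG ATCC cells (Homo sapiens), read by thymidine incorporation (on this read-out higher numbers stand for weaker inhibition and lower numbers for stronger inhibition), compound 3 `CCCCCCCCCCCCCCCCO[C@H]1O[C@H](COCC(O)CO)[C@@H](O)[C@H](O)[C@H]1NC(=O)CCCC` gives 4.6 uM. Compound 1 `CCCCCCCCCCCCCCCCO[C@H]1O[C@H](COCC(CO)(CO)COS(=O)(=O)O)[C@@H](O)[C@H](O)[C@H]1NC(=O)CCCC` gives 3.2 uM and compound 2 `CCCCCCCCCCCCCCCCO[C@H]1O[C@H](COC[C@H](O)CO)[C@@H](O)[C@H](O)[C@H]1NC(=O)CCCC` gives 4.9 uM, so all three lie within the scatter of one another.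

Compound 4 `CCCCCCCCCCCCCCCCO[C@H]1O[C@H](COC[C@@H](O)CO)[C@@H](O)[C@H](O)[C@H]1NC(=O)CCCC` carries one structural difference: the two compounds have the same atoms and bonds; at least one stereo element is drawn with a configuration in one of them and without one in the other: 1 of 6 stereo elements differ; a stereocentre at a saturated chain carbon is drawn without a configuration in compound 3 and S in compound 4.

The closest measured step is a 1.1-fold lower number from compound 2 to compound 3 (0.03 log units; within the scatter), at the same stereocentre, drawn R on one side and without a configuration on the other. Replacing the side group gives a 1.5-fold higher number from compound 1 to compound 2 (0.19 log units; within the scatter) and a 1.4-fold higher number from compound 1 to compound 3 (0.16 log units; within the scatter), which bear on this change only loosely.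

No step beyond the scatter is expected in this assay, and no direction can be favoured. The expected step is a 1.0-fold lower number from compound 3 to compound 4 (0.01 log units; within the scatter). For compound 4 the estimate is 4.5 uM, with an expected range of 2.6 uM to 8 uM.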

Compound 4, concentration for 50% inhibition: 5.6 uM
Beside the measured number, compound 4's estimate is 1.2-fold (0.09 log units) below it; the measured number falls inside the stated range.
By their numbers in this assay, from the lowest: compounds 1, 3, 2 and 4 (each within the scatter of the next).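

In this assay, the S and R drawings at this saturated chain carbon can now be compared directly: the step is a 1.1-fold higher number from compound 2 to compound 4 (0.06 log units; within the scatter), and from the drawing without a configuration it is a 1.2-fold higher number from compound 3 to compound 4 (0.09 log units; within the scatter). With 1,2-dihydroxyethyl in place, the configuration at this stereocentre therefore produces no step beyond the scatter. The S compound also stays within the scatter of the sulfated side group, with a 1.8-fold higher number from compound 1 to compound 4 (0.24 log units; within the scatter).

As far as these compounds go, it remains open whether an amine or a carboxylic acid in place of the 1,2-dihydroxyethyl would give a step beyond the scatter. From the compounds shown here alone, it also remains open whether the configuration at this carbon would then matter.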